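Swapping a Nitromethyl Group for a Fluoropyridine

The source may hold more compounds than are shown below. What is called first, only, known or untested is meant among the compounds shown, and "the series" means these compounds.

Measured so far:
compound 1 `COc1ccc(CN2C(=O)C(O)(C[N+](=O)[O-])c3cc(OC(F)(F)F)ccc32)cc1`: 75%
compound 2 `Cn1cc(-c2ccc(CN3C(=O)C(=O)c4ccccc43)c(F)c2)cn1`: 45%
compound 3 `O=C1C(=O)N(CCOc2ccc(Oc3ccccc3)cc2)c2ccc(OC(F)(F)F)cc21`: 93%

In an assay on isolated protein for positive allosteric modulation of muscarinic acetylcholine receptor M5 (Homo sapiens) (on this read-out higher numbers stand for larger maximal responses and lower numbers for smaller maximal responses), compound 1 stands second highest of these three numbers. Compound 3 lies above it by a margin beyond the scatter, and compound 2 lies below it by a larger margin, also beyond the scatter. The not yet measured compound 4 `COc1ccc(CN2C(=O)C(O)(c3ccc(F)nc3)c3cc(OC(F)(F)F)ccc32)cc1` keeps the core of compound 1 and differs in one place: 6-fluoropyridin-3-yl in place of nitromethyl on a saturated ring carbon. The nitromethyl group leaves and a 6-fluoropyridin-3-yl group enters on a saturated ring carbon. For the measured compounds named here, no measured pair shows this kind of change, so the size and direction of the step are open. The step of a number 5 percentage points lower from compound 1 to compound 4 (within the scatter) is expected to stay within the scatter. For compound 4 a value of 70% is estimated, within 45% to 95%.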

Compound 4, largest response reached (Emax), in percent of the reference or control that the assay uses: 74%
Estimate against measurement, compound 4: 4 percentage points below; the measured number falls inside the stated range.
By their numbers in this assay, from the lowest: compound 2; then compounds 4 and 1 (each within the scatter of the next); then compound 3.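

Replacing nitromethyl with 6-fluoropyridin-3-yl gives a number 1 percentage points lower from compound 1 to compound 4 (within the scatter) in this assay, so this saturated ring carbon can carry a six-membered aromatic ring as well as a small group with no ring, and the two maximal responses cannot be told apart. Nothing given here explains why the two compounds read alike. Still open, from the compounds shown here alone, is how an amine, a carboxylic acid or a longer chain on this carbon would read. Also open, going by these compounds, is whether the same swap would read alike with another group in place of the 4-methoxybenzyl group.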